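Benzyl for cyclohexyl on the amide-type nitrogen

The source may hold more compounds than are shown below. What is called first, only, known or untested is meant among the compounds shown, and "the series" means these compounds.

Measured so far in an assay on membranes from Sf9 cells for displacement of a labelled ligand from histamine H2 receptor (Homo sapiens), read by scintillation counting, with a stated time of 60 min; on this read-out lower numbers stand for stronger inhibition and higher numbers for weaker inhibition:
compound 1 `CCCNC(=O)/N=C(\N)Nc1cccc(-c2csc(N)n2)c1` gives 5250 nM
compound 2 `Cc1nc(N)sc1CCCN/C(N)=N/C(=O)NC1CCCCC1` gives 170 nM
compound 3 `Cc1nc(N)sc1CCCN/C(N)=N/C(=S)NC(c1ccccc1)c1ccccc1` gives 603 nM

Compound 2 stands lowest of the three numbers in this assay; the number for compound 3 lies beyond the scatter above it, and the number for compound 1 further still. Compound 4 `Cc1nc(N)sc1CCCN/C(N)=N/C(=O)NCc1ccccc1` is not yet measured. Its change from compound 2 is benzyl in place of cyclohexyl on an amide-type nitrogen. Going by the values given here, no measured pair isolates this one change, and compound 3 also differs at the thiocarbonyl and the benzhydryl, so it gives no clean guide. The step of a 1.9-fold higher number from compound 2 to compound 4 (0.27 log units; within the scatter) is expected to be small, at most a modest rise, close to the scatter. Compound 4 is therefore expected at 320 nM, within a range of 110 nM to 950 nM.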

Compound 4, inhibition constant: 69.2 nM
For compound 4 the middle estimate is 4.6-fold (0.67 log units) above the measured one; measured number outside the range, below it.
By their numbers in this assay, from the lowest: compound 4; then compound 2; then compound 3; then compound 1.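

In this assay, the change gives the series its first single-place comparison: a 2.5-fold lower number from compound 2 to compound 4 (0.39 log units; beyond the scatter). The amide-type nitrogen therefore accepts an aromatic benzyl as well as a saturated cyclohexyl, and the benzyl gives the lower number, a difference beyond the scatter. No measurement shown accounts for this step.

Going by these compounds, it remains open whether phenyl directly on this nitrogen, or the longer phenethyl, would move the number further. On these data alone, the effect of a thiocarbonyl in place of the carbonyl on this benzyl compound also remains open.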